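Iodo for ethynyl on a methylamino core

The source may report more compounds than this note shows. Statements on the series, on what has been measured and on what is new or still open speak of the compounds shown alone.

Compound 1, `Cc1ncnc2c1c(I)cn2[C@@H]1O[C@H](CO)[C@@H](O)[C@H]1O`, gives 13300 nM in an ADME assay on MRC5 cells (Homo sapiens), read by MTT assay, with a stated time of 72 h; on this read-out higher numbers stand for weaker inhibition and lower numbers for stronger inhibition. Compound 2, `C#Cc1cn([C@@H]2O[C@H](CO)[C@@H](O)[C@H]2O)c2ncnc(C)c12`, gives 1440 nM. Compound 3, `C#Cc1cn([C@@H]2O[C@H](CO)[C@@H](O)[C@H]2O)c2ncnc(NC)c12`, reaches only a limit, > 100000 nM.

The change iodo in place of ethynyl on an aromatic carbon produced a 9.2-fold higher number from compound 2 to compound 1 (0.97 log units; beyond the scatter). The two cores differ by methylamino in place of methyl on an aromatic carbon, which gave an at least 69-fold higher number from compound 2 to compound 3 (1.84 log units; beyond the scatter), compound 3 sitting at the limit of > 100000 nM in this assay, at which 1 of the 3 values shown sits.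

Compound 4, `CNc1ncnc2c1c(I)cn2[C@@H]1O[C@H](CO)[C@@H](O)[C@H]1O`, is not yet measured. It carries the change (iodo in place of ethynyl on an aromatic carbon), the same change as that from compound 2 to compound 1, on the core of compound 3. Compound 4 is expected to show a step that the limit leaves unreadable from compound 3 to compound 4, an estimate that rests on the weakening seen in a 9.2-fold higher number from compound 2 to compound 1 (0.97 log units; beyond the scatter) and on compound 3 already giving only the limit > 100000 nM. The estimate for compound 4 in this assay is therefore 600000 nM, between 100000 nM and 4000000 nM, most likely reported as a limit.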

Compound 4, half-maximal inhibitory concentration: > 100000 nM
Compound 4 gave a limit, no number (the forecaster's own chance of this, stated with the estimate: 90%); the middle value is on the limit's open side.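

In this assay methylamino in place of methyl raised the number on the iodo core as well, with an at least 7.5-fold higher number from compound 1 to compound 4 (0.87 log units; beyond the scatter), so the direction seen on the ethynyl core holds on both cores: the same change on two cores in this assay, an at least 69-fold higher number (1.84 log units; beyond the scatter) from compound 2 to compound 3 and an at least 7.5-fold higher number (0.87 log units; beyond the scatter) from compound 1 to compound 4; the limit leaves it open whether they differ

The step from compound 3 to compound 4 cannot be read, since both compounds stand only at a limit: the limit of > 100000 nM in this assay, at which 2 of the 4 values shown sit.

The series therefore shows a shared direction for the methylamino change, but not whether its size carries over, nor whether iodo in place of ethynyl weakens inhibition on the methylamino core as it does on the methyl core.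

As far as these compounds go, it stays open whether a plain amino or an ethylamino group in place of methylamino would give values short of the limit. Such values could make the iodo for ethynyl change readable on that core.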